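A few compounds are considered here, and "the series" means these few. Any claim that something is new, unique, unknown or untested is made for them only; others in the source may bear on it.

Working notes on the series, read in a physicochemical assay for solubility, read by nephelometry, in phosphate buffer, measured as kinetic solubility, at pH 6.5; a lower number here means a less soluble compound, a higher number a more soluble compound. Within the data shown here, compound 1 `O=C(Nc1cccc(C(=O)O)c1)Nc1ccc(F)c(C(F)(F)F)c1` gives 12.5 ug/mL, the only true number so far. Compound 2 `O=C(Nc1ccc(F)c(C(F)(F)F)c1)Nc1ccccn1` gives < 1.6 ug/mL. That reading is a limit of the assay and not a number. Among the measured compounds shown here, no measured pair differing in one place is available yet, so no measured step can size the next change.

Compound 3 `O=C(Nc1ccncc1)Nc1ccc(F)c(C(F)(F)F)c1` keeps the shared core of compound 2 and differs from it in one place, on an amide-type nitrogen: pyridin-4-yl in place of pyridin-2-yl on an amide-type nitrogen. Pyridin-4-yl stands in place of pyridin-2-yl, with the same atoms joined differently.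

For the measured compounds named here, with no step to go on, only a modest upward move in this assay is expected. Going by the values given here, compound 1 at 12.5 ug/mL is the sole measured number to set a scale, so the expectation stays under that value. The expected step is an at least 2.5-fold higher number from compound 2 to compound 3 (0.39 log units; beyond the scatter). A second reading that returns only a limit remains possible. For compound 3 the estimated solubility is 4 ug/mL, with an expected range of 1.6 ug/mL to 15 ug/mL.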

Compound 3, solubility: 6.3 ug/mL
Estimate against measurement, compound 3: 1.6-fold (0.20 log units) below; the range from low to high includes it.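

In this assay, among these compounds, pyridin-4-yl in place of pyridin-2-yl on an amide-type nitrogen gives an at least 3.9-fold higher number from compound 2 to compound 3 (0.59 log units; beyond the scatter), the first measured step and one that shows this place is sensitive to how the ring is joined. The leaving and entering groups have the same heavy atoms and the same counts of hydrogen-bond donors and acceptors, so this isomeric swap alone separates the two readings, and compound 3 gives a true number, 6.3 ug/mL. The size of the step can be stated only as a lower bound, because the reading for compound 2 is a limit of the assay and not a number: the limit of < 1.6 ug/mL in this assay, at which 1 of the 3 values shown sits.

What the compounds shown leave open is how pyridin-3-yl would read on the same amide-type nitrogen, and whether an amine on the pyridin-4-yl ring would move the reading further from that of compound 3. Going by these compounds, the full size of the step also remains open, and this single pair cannot tell whether the same swap would give a similar step on any other core.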